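Fluorine on the aryl ether in a spirocyclic series

The source may report more compounds than this note shows. Statements on the series, on what has been measured and on what is new or still open speak of the compounds shown alone.

Measured so far:
compound 1, `CC(C)OC(=O)N1CCC2(CC1)CC(CCCOc1ccc(S(C)(=O)=O)cc1)C2`, 78 nM
compound 2, `CC(C)OC(=O)N1CCC2(CC1)CC(CCCOc1ccc(S(C)(=O)=O)c(F)c1)C2`, 18 nM
compound 3, `CCc1cnc(N2CCC3(CC2)CC(CCCOc2ccc(S(C)(=O)=O)cc2)C3)nc1`, 31 nM

All three were read in a functional assay on cells for agonist activity at Glucose-dependent insulinotropic receptor (Homo sapiens), read by HTRF and cAMP accumulation, with a stated time of 30 min; a lower number here means that less compound is needed, a higher number that more compound is needed for the effect. Compound 1 carries the isopropoxycarbonyl on the ring nitrogen; compound 2 differs from it by fluoro in place of hydrogen on an aromatic carbon, a change that gave a 4.3-fold lower number from compound 1 to compound 2 (0.64 log units; beyond the scatter). Compound 3 differs from compound 1 by 5-ethylpyrimidin-2-yl in place of isopropoxycarbonyl on an amine nitrogen in a ring, which gave a 2.5-fold lower number from compound 1 to compound 3 (0.40 log units; beyond the scatter). Compound 2 and compound 3 lie within the scatter of each other.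

Compound 4, `CCc1cnc(N2CCC3(CC2)CC(CCCOc2ccc(S(C)(=O)=O)cc2F)C3)nc1`, is not yet measured. It differs from compound 3 by fluoro in place of hydrogen on an aromatic carbon. This is the same kind of change as that from compound 1 to compound 2, but not the same: in compound 2 the fluoro sits ortho to a methylsulfonyl group and meta to a large group, whereas in compound 4 it sits ortho to a large group and meta to a methylsulfonyl group. Going by the values given here, the only fluoro step seen rests on compound 1 and compound 2 with a 4.3-fold lower number from compound 1 to compound 2 (0.64 log units; beyond the scatter); no step at the new place is known. Compound 4 is therefore expected to move by a 1.9-fold lower number from compound 3 to compound 4 (0.29 log units; within the scatter), a smaller step than the earlier one, with wide uncertainty. Compound 4 is estimated at 16 nM, between 6 nM and 45 nM.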

Compound 4, half-maximal effective concentration: 225 nM
Beside the measured number, compound 4's estimate is 14-fold (1.15 log units) below it; the whole stated range lies below it.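

In this assay, fluoro in place of hydrogen on the aromatic carbon ortho to a large group and meta to a methylsulfonyl group gave a 7.3-fold higher number from compound 3 to compound 4 (0.86 log units; beyond the scatter), a change of direction from the earlier fluoro step. The two steps therefore cannot be treated as one transferable effect of adding fluoro, and the comparison reads: the same change on two cores in this assay, a 4.3-fold lower number (0.64 log units; beyond the scatter) from compound 1 to compound 2 and a 7.3-fold higher number (0.86 log units; beyond the scatter) from compound 3 to compound 4, 31-fold (1.50 log units) apart, beyond the scatter of two such steps. This does not show whether the core or the place of the fluoro on the ring decides the outcome, as the two steps differ in both and the compounds shown do not separate them.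

Still open, on these data alone, is how the 5-ethylpyrimidin-2-yl series responds to fluoro at the ring place it holds in compound 2, and how the isopropoxycarbonyl series responds to fluoro at the ring place it holds in compound 4, the two pairs that would separate core from place. Also open, as far as these compounds go, is whether a chloro, a methyl or a nitrile at the fluoro's place in compound 4 would follow the same course as fluoro.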